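This account rests on a few compounds, and the source may have more. Where it says the series, first, only, none or still open, it means among the compounds named here.

Compound 3 `c1ccc2c(c1)CCC2c1ncc[nH]1` carries no substituent at all beyond its two fused rings and the imidazolyl group. In a functional assay on CHO cells for agonist activity at Alpha-1D adrenergic receptor (Homo sapiens), read by FLIPR and calcium flux (on this read-out higher numbers stand for an effect only at larger amounts of compound and lower numbers for an effect already at smaller amounts), compound 3 gives > 10000 nM, which is a limit of the measurement and not a number. Two further compounds share that outcome. Compound 1 `COc1c(C)ccc2c1CCC2c1ncc[nH]1`, which bears a methoxy group and a methyl group, gives in this assay a value of > 10000 nM, again a limit. Compound 2 `CS(=O)(=O)Nc1c(Cl)ccc2c1CCCC2c1ncc[nH]1`, which bears a methanesulfonamide and a chlorine, gives in this assay a value of > 10000 nM, also a limit. The evidence is therefore the limit of > 10000 nM in this assay, at which 3 of the 3 values shown sit: compound 3 stands with both others at the limit, neither separated from them nor ranked against them.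

Compound 4 `c1cc(-c2nccs2)c2c(c1)C(c1ncc[nH]1)CC2` differs from compound 3 in one place: 1,3-thiazol-2-yl in place of hydrogen on an aromatic carbon, ortho to a fused ring and meta to a fused ring. Among the compounds with values here, no measured pair shows what such a change does in this assay, and the three limits give no direction. Because the limit of > 10000 nM in this assay, at which 3 of the 3 values shown sit, is all that has been seen, the step from compound 3 to compound 4 is expected to be an at least 1.2-fold lower number from compound 3 to compound 4 (0.09 log units; that floor lies within the scatter), none beyond the scatter. The estimate for compound 4 in this assay is 8000 nM, with a range from 1500 nM to 30000 nM, and a real chance that only a limit is reported again.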

Compound 4, half-maximal effective concentration: 3190 nM
The estimate for compound 4 lay 2.5-fold (0.40 log units) above the measured number; the measured number falls inside the stated range.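

In this assay, within the data shown here, placing 1,3-thiazol-2-yl on an aromatic carbon, ortho to a fused ring and meta to a fused ring, gives an at least 3.1-fold lower number from compound 3 to compound 4 (0.49 log units; beyond the scatter), a step beyond the scatter and the first measured change in this small set. Among these compounds, it shows that this position can take a five-membered aromatic ring without losing the effect, and that the change moves the read-out from a limit to a number, something the earlier compounds did not show. Compound 4 thus stands apart from the rest, but the true size of the step stays unknown and the step gives only its smallest possible size, with the other end resting on this: the limit of > 10000 nM in this assay, at which 3 of the 4 values shown sit.

Going by these compounds, what remains open is whether the effect belongs to the 1,3-thiazol-2-yl itself or would also appear with a phenyl, an amine or a carboxylic acid on the same aromatic carbon. The compounds shown also leave open whether the same 1,3-thiazol-2-yl on another aromatic carbon of the shared core would give a number at all.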